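The source may report more compounds than this note shows. Statements on the series, on what has been measured and on what is new or still open speak of the compounds shown alone.

Compounds measured in an assay on isolated protein for inhibition of Rho-associated protein kinase 1 (Homo sapiens), tested at 30 uM; on this read-out lower numbers stand for less inhibition and higher numbers for more inhibition at the one concentration tested (going by the name of the read-out):
compound 1, `Cn1cnc2c(Sc3ccccc3)ncnc21`, gives 6%
compound 2, `Cn1c(-c2ccccc2)nc2c(Sc3ccccc3)ncnc21`, gives 1%
compound 3, `CSc1ccc(-c2nc3c(Sc4ccccc4)ncnc3n2C)cc1`, gives 0%

Compound 3 has the lowest number of the three, but the steps of a number 6 percentage points lower from compound 1 to compound 3 (within the scatter) and a number 1 percentage points lower from compound 2 to compound 3 (within the scatter) are both within the scatter, so the three compounds cannot be set apart. Compound 4, `Cn1c(Br)nc2c(Sc3ccccc3)ncnc21`, differs from compound 3 by bromo in place of 4-(methylsulfanyl)phenyl on an aromatic carbon. Among the measured compounds shown here, the steps that bear on this position are a number 5 percentage points lower from compound 1 to compound 2 (within the scatter) and a number 6 percentage points lower from compound 1 to compound 3 (within the scatter), both within the scatter, so changes at this carbon have so far left this assay unmoved. The step of a number 4 percentage points higher from compound 3 to compound 4 (within the scatter) is therefore expected to lie within the scatter. Compound 4 is estimated at 4%, with a range from 0% to 15%.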

Compound 4, a percentage reported as inhibition, at one concentration (the size of the read-out at that concentration, not a potency): 0%
Compound 4: middle estimate off by 4 percentage points, on the high side; low and high end bracket the measured number.
By their numbers in this assay, from the lowest: compounds 3, 4, 2 and 1 (each within the scatter of the next).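

In this assay there is no change at the digits printed from compound 3 to compound 4 (within the scatter) and there is a number 1 percentage points lower from compound 2 to compound 4 (within the scatter) with bromo on this carbon between two ring nitrogen atoms, so a single atom without a ring cannot be told apart from phenyl or 4-(methylsulfanyl)phenyl. Against hydrogen there is a number 6 percentage points lower from compound 1 to compound 4 (within the scatter) as well, which leaves all four substituents at this position within the scatter of one another. No supporting evidence is available to explain this flat result. On these data alone, whether an amine or a carboxylic acid on this carbon would move the number beyond the scatter remains open.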